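Cyclohexyl to Benzyl: Expected Shift in Cytotoxicity

The compounds below may be only part of what the source reports. "The series", "measured", "known", "first", "only" and "open" are said of these compounds alone.

Compound 1 `O=c1nc(NCc2ccc(F)cc2)oc2c([N+](=O)[O-])cc(C(F)(F)F)cc12`: > 64 ug/mL
Compound 2 `O=c1nc(NC2CCCCC2)oc2c([N+](=O)[O-])cc(C(F)(F)F)cc12`: 5.39 ug/mL

Of the compounds shown here, two sharing one core have been tested in an ADME assay on Vero cells (Chlorocebus sabaeus) for cytotoxicity, read by MTT assay, with a stated time of 48 h; on this read-out higher numbers stand for weaker inhibition and lower numbers for stronger inhibition. Compound 1 gives only a limit of the assay, > 64 ug/mL. For the measured compounds named here, compound 2 gives 5.39 ug/mL, the only full number among the two values shown, so it stands as the one compound with measurable cytotoxicity in this assay. Going by the values given here, the one measured step is an at least 11-fold lower number from compound 1 to compound 2 (1.07 log units; beyond the scatter), and its starting value sits at the limit of > 64 ug/mL in this assay, at which 1 of the 2 values shown sits. Compound 3 `O=c1nc(NCc2ccccc2)oc2c([N+](=O)[O-])cc(C(F)(F)F)cc12` differs from compound 2 by benzyl in place of cyclohexyl on a nitrogen on an aromatic ring. This change largely reverses the measured step: an aromatic ring returns, as in compound 1, the fluorine aside. Since that step was large, compound 3 is expected to move back toward compound 1, by an estimated 7.4-fold higher number from compound 2 to compound 3 (0.87 log units; beyond the scatter). The estimate for compound 3 is 40 ug/mL, with a range from 10 ug/mL to 128 ug/mL, and a fair chance that only a limit is reported.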

Compound 3, half-maximal inhibitory concentration: 25.4 ug/mL
Estimate against measurement, compound 3: 1.6-fold (0.20 log units) above, within the range that was stated.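

In this assay, the group on this nitrogen matters even among ring-bearing groups, as benzyl in place of cyclohexyl gives a 4.7-fold higher number from compound 2 to compound 3 (0.67 log units; beyond the scatter). The fluoro group counts as well, since hydrogen in its place on an aromatic carbon gives an at least 2.5-fold lower number from compound 1 to compound 3 (0.40 log units; beyond the scatter), so the large first step cannot be read as the swap of cyclohexyl for a benzyl-type group alone. The size of this second step stays open-ended, as it starts from a limit: the limit of > 64 ug/mL in this assay, at which 1 of the 3 values shown sits.

The compounds shown do not tell whether chloro or methoxy on that aromatic carbon would read like fluoro or like hydrogen. They also leave open how an open-chain butyl group or the longer phenethyl group on the nitrogen would compare, and they give no measured reason for either step.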